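Benzyl for phenyl on the ring nitrogen: cytotoxicity outlook

This account rests on a few compounds, and the source may have more. Where it says the series, first, only, none or still open, it means among the compounds named here.

Compound 1 `O=C1Nc2ccccc2/C1=N/NC(=S)Nc1ccccc1`, compound 2 `CN1C(=O)/C(=N\NC(=S)Nc2ccccc2)c2ccccc21` and compound 3 `O=C1/C(=N\NC(=S)Nc2ccccc2)c2ccccc2N1c1ccccc1` share one core and differ only in the group on an amide-type nitrogen in a ring. In an ADME assay on RD cells (Homo sapiens) for cytotoxicity (on this read-out higher numbers stand for lower toxicity in this test and lower numbers for higher toxicity in this test), compound 1 gives > 25000 nM, which is a limit of the assay. Compound 2 gives > 25000 nM, likewise a limit. Compound 3 gives > 25000 nM, again a limit. For that reason the steps a step that the two limits leave unreadable from compound 1 to compound 2, a step that the two limits leave unreadable from compound 1 to compound 3 and a step that the two limits leave unreadable from compound 2 to compound 3 cannot be sized, and the limit of > 25000 nM in this assay, at which 3 of the 3 values shown sit, is the whole of the evidence. Compound 4 `O=C1/C(=N\NC(=S)Nc2ccccc2)c2ccccc2N1Cc1ccccc1` arises from compound 3 by benzyl in place of phenyl on an amide-type nitrogen in a ring. Compound 4 is expected to stay at the same limit, so the step that the limit leaves unreadable from compound 3 to compound 4 is expected to be unreadable as well. The estimate for compound 4 is 30000 nM, between 12000 nM and 100000 nM.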

Compound 4, half-maximal cytotoxic concentration: > 25000 nM
Compound 4: only a limit was reported; the forecaster's own chance of this, stated with the estimate: 85%; the middle value does not contradict the limit.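

No step can be read between compound 4 and compound 1, compound 2 or compound 3, as all four share one limit: the limit of > 25000 nM in this assay, at which 4 of the 4 values shown sit. The compounds shown leave open whether the group on the amide-type nitrogen in a ring affects cytotoxicity at all.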